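The compounds below may be only part of what the source reports. "The series", "measured", "known", "first", "only" and "open" are said of these compounds alone.

Compound 1 `CCCOC(=O)C1=C(C)NC(=O)NC1c1ccoc1`: 50%
Compound 2 `CC(=O)C1=C(C)NC(=O)NC1c1ccoc1`: 6%
Compound 3 `CC1=C(C(=O)NC(C)C)C(c2ccoc2)NC(=O)N1`: 1%

In an assay on membranes from CHO cells for displacement of a labelled ligand from adenosine receptor A1 (Homo sapiens), read by scintillation counting, with a stated time of 60 min, tested at 1 uM (a lower number here means less inhibition, a higher number more inhibition at the concentration tested (going by the name of the read-out)), compound 3 gives 1%, the lowest of the three numbers, though compound 2 sits within the scatter of it and only compound 1 stands well above. Compound 4 `CC1=C(C(=O)SC(C)C)C(c2ccoc2)NC(=O)N1` differs from compound 3 by isopropylsulfanyl in place of isopropylamino on a carbonyl carbon. Going by the values given here, the steps that bear on this all change the group on the same carbonyl carbon: a number 44 percentage points lower from compound 1 to compound 2 (beyond the scatter) and a number 49 percentage points lower from compound 1 to compound 3 (beyond the scatter) were large, while a number 5 percentage points lower from compound 2 to compound 3 (within the scatter) stayed within the scatter. Among the compounds with values here, no measured step exchanges an amine for a sulfur group, so the guidance is loose. Since compound 3 already sits near the bottom of the scale, little movement beyond the scatter is expected, a number 7 percentage points higher from compound 3 to compound 4 (within the scatter). Compound 4 is therefore estimated at 8%, within 0% to 25%.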

Compound 4, a percentage reported as inhibition, at one concentration (the size of the read-out at that concentration, not a potency): 9%
Compound 4: middle estimate off by 1 percentage points, on the low side, and the stated range covers the measured number.
By their numbers in this assay, from the lowest: compounds 3, 2 and 4 (each within the scatter of the next); then compound 1.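

In this assay, putting isopropylsulfanyl in place of isopropylamino on this carbonyl carbon leaves the read-out within the scatter (a number 8 percentage points higher from compound 3 to compound 4 (within the scatter)), and the same holds for isopropylsulfanyl against methyl (a number 3 percentage points higher from compound 2 to compound 4 (within the scatter)). The propoxy group still stands apart (a number 41 percentage points lower from compound 1 to compound 4 (beyond the scatter)), so a sulfur link, like a nitrogen link, does not match the read-out of the oxygen-linked propoxy group. Nothing available here explains this difference.

As far as these compounds go, it remains open whether the oxygen link or the chain matters more. An isopropoxy group and a propylsulfanyl group on the same carbonyl carbon would help separate the two.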